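The compounds below may be only part of what the source reports. "The series", "measured", "known", "first", "only" and "open" are said of these compounds alone.

Measured so far in a functional assay on HL-60 cells (Homo sapiens) for antiproliferative activity, read by MTT assay, tested at 100 ug/mL; a lower number here means less inhibition, a higher number more inhibition at the concentration tested (going by the name of the read-out):

compound 1, `COc1cc(OC)nc(NS(=O)(=O)C2CCCCC2=O)n1`, 2.62%
compound 2, `Cc1ccc(NS(=O)(=O)C2CCCCC2=O)c(C)c1`, 12.2%
compound 3, `O=C1CCCCC1S(=O)(=O)Nc1ccc(Cl)cc1C(F)(F)F`, 78.6%

Among these three, compound 3 gives the highest inhibition. Its nearest neighbour on the numbers is compound 2, which lies a distance beyond the scatter below it; the furthest is compound 1, whose number sits still lower, also beyond the scatter. Compound 3 thus stands alone at the top, with the other two well separated from it.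

The step considered next leads from compound 3 to compound 4, `O=C1CCCCC1S(=O)(=O)Nc1ccc(Cl)cc1`, which has not yet been tested in this assay. The structures differ in one place: hydrogen in place of trifluoromethyl on an aromatic carbon. The trifluoromethyl leaves and nothing but a hydrogen enters, on the aromatic carbon ortho to a large group and meta to the chloro group.

Among the measured compounds shown here, no step between measured compounds matches this change, so there is no direct guide to its size. Still, compound 4 keeps less of compound 3 than any measured pair shares, and the account expects a downward step in this assay, beyond the scatter, estimated as a number 38.6 percentage points lower from compound 3 to compound 4 (beyond the scatter). For compound 4 the expected inhibition is 40%, within a range from 10% to 72%.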

Compound 4, a percentage reported as inhibition, at one concentration (the size of the read-out at that concentration, not a potency): -13%
Compound 4: the middle estimate sits 53 percentage points above what was measured, outside the stated range (below it).
By their numbers in this assay, from the lowest: compound 4; then compounds 1 and 2 (each within the scatter of the next); then compound 3.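

In this assay, among the compounds shown here, the single exchange of hydrogen for trifluoromethyl gives a number 91.6 percentage points lower from compound 3 to compound 4 (beyond the scatter) and is the first one-place change available, showing that this aromatic carbon, ortho to a large group and meta to a chloro group, is far from indifferent to what it carries. Compound 4 gives -13% while keeping the chloro group and the rest of compound 3, so within this pair the high inhibition of compound 3 does not persist once the trifluoromethyl has left. The compounds shown offer no measurement that explains why this position responds so strongly.

Going by these compounds, whether the inhibition depends on trifluoromethyl itself or could also be held by a methyl, a methoxy, a nitrile or a single fluorine on the same aromatic carbon remains open. Equally open, on these data alone, is whether the step keeps its size when the chloro group is exchanged for hydrogen or an amine, since this change is seen here only with the chloro group in place.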